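Carbamoyloxy in Place of 3-Fluoro-4-hydroxyphenyl

The compounds below may be only part of what the source reports. "The series", "measured", "known", "first", "only" and "open" are said of these compounds alone.

In a functional assay on V79-379A cells (Cricetulus griseus) for cytotoxicity, read by MTT assay, in the presence of a further agent that is not named here (on this read-out higher numbers stand for weaker inhibition and lower numbers for stronger inhibition), two compounds sharing one core have been measured. Compound 1 (`COC1=CC(=O)c2c(c(COc3ccc(F)cc3)c(C)n2C)C1=O`) gives 31000 nM, and compound 2 (`COC1=CC(=O)c2c(c(Cc3ccc(O)c(F)c3)c(C)n2C)C1=O`) gives 470000 nM, the higher of the two numbers. The next compound, compound 3 (`COC1=CC(=O)c2c(c(COC(N)=O)c(C)n2C)C1=O`), has not yet been measured. It differs from compound 2 by carbamoyloxy in place of 3-fluoro-4-hydroxyphenyl on a saturated chain carbon bound to an aromatic carbon. Going by the values given here, only one measured step bears on this change. That step, a 15-fold higher number from compound 1 to compound 2 (1.18 log units; beyond the scatter), is large and introduced the 3-fluoro-4-hydroxyphenyl group that compound 3 now loses. A single step offers limited guidance, yet a sizeable move towards lower numbers in this assay is expected, returning near compound 1 at 31000 nM. The expected step is a 12-fold lower number from compound 2 to compound 3 (1.07 log units; beyond the scatter). For compound 3 the estimated value is 40000 nM, with an expected range of 8000 nM to 200000 nM.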

Compound 3, half-maximal inhibitory concentration: 25000 nM
For compound 3 the middle estimate is 1.6-fold (0.20 log units) above the measured one; low and high end bracket the measured number.
By their numbers in this assay, from the lowest: compounds 3 and 1 (each within the scatter of the next); then compound 2.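

In this assay, carbamoyloxy on the saturated chain carbon bound to an aromatic carbon gives a 19-fold lower number from compound 2 to compound 3 (1.27 log units; beyond the scatter), so the high number of compound 2 does not carry over to this much smaller group, which has no ring. Carbamoyl in place of 4-fluorophenyl on an oxygen on a saturated carbon gives a 1.2-fold lower number from compound 1 to compound 3 (0.09 log units; within the scatter), which lies within the scatter and shows that the aromatic ring of compound 1 is not needed to keep a number of this size. No available evidence accounts for these differences.

Compound 2 differs from compound 1 in both the oxygen on the chain carbon and the ring substituents, so the compounds shown cannot separate these two changes. On these data alone, how an amine or an acetoxy group on this carbon would read also remains open.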